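The source may hold more compounds than are shown below. What is called first, only, known or untested is meant among the compounds shown, and "the series" means these compounds.

Measured so far in an ADME assay on MT4 cells (Homo sapiens) for cytotoxicity, read by MTT assay; a higher number here means that more compound is tolerated, a lower number that less compound is tolerated:
Compound 1 `O=C(CSc1nnnn1-c1cccc2ccccc12)N/N=C/c1cccs1`: > 316000 nM, a limit
Compound 2 `O=C(CSc1nnnn1-c1cccc2ccccc12)N/N=C/c1ccc([N+](=O)[O-])cc1`: >= 260000 nM, a limit

Compound 2 has no exact position on this scale. Its result of >= 260000 nM is a limit and not a number. Compound 1 offers no exact value for comparison, since its > 316000 nM is also a limit.

The next compound to be tested is compound 3 `COc1ccc(/C=N/NC(=O)CSc2nnnn2-c2cccc3ccccc23)c(OC)c1`. It has 2,4-dimethoxyphenyl in place of 4-nitrophenyl on a carbon with a double bond to nitrogen. The core of compound 2 stays the same.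

Going by the values given here, one measured step bears on this change, because it also swaps the group at that place: a step that the two limits leave unreadable from compound 1 to compound 2. It gives no size to carry forward, so the data offer no evidence for a change in either direction. No step beyond the usual scatter is therefore expected in this assay.

Compound 3 is expected at about 250000 nM, with an estimated range of 100000 nM to 350000 nM. This estimate means an expected at least 1.0-fold lower number from compound 2 to compound 3 (0.01 log units; that floor lies within the scatter).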

Compound 3, half-maximal cytotoxic concentration: 28300 nM
Estimate against measurement, compound 3: 8.8-fold (0.95 log units) above; the measured number lies below the stated range.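

Going by these compounds alone, compound 3 gives the first exact value in this assay, and it shows that the group on a carbon with a double bond to nitrogen can change how much compound the cells tolerate. Putting 2,4-dimethoxyphenyl in place of 4-nitrophenyl gives an at least 9.1-fold lower number from compound 2 to compound 3 (0.96 log units; beyond the scatter), and putting it in place of thiophen-2-yl gives an at least 11-fold lower number from compound 1 to compound 3 (1.04 log units; beyond the scatter), whereas the step between the two earlier compounds cannot be read. Each of these new steps is a minimum, because compound 2 and compound 1 are each recorded only as a limit, printed here for compound 2 and then for compound 1: the limit of >= 260000 nM in this assay, at which 1 of the 3 values shown sits, and (the limit of > 316000 nM in this assay, at which 1 of the 3 values shown sits).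

The compounds shown do not separate the two methoxy groups, so it remains open whether a phenyl ring carrying a single methoxy group would give a number closer to that of compound 3 or closer to the limits of the earlier compounds. Going by these compounds, it also remains open how a plain phenyl ring, or a phenyl ring carrying an amine or a carboxylic acid, would behave at this place on the shared core.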